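Chlorobenzyl position change on the hydrazone series

This account rests on a few compounds, and the source may have more. Where it says the series, first, only, none or still open, it means among the compounds named here.

Measured so far:
compound 1 `CCCSc1nc(N/N=C(\C)c2ccccc2O)c2nnn(Cc3ccccc3Cl)c2n1` — > 64000 nM
compound 2 `CCCSc1nc(N/N=C(\C)c2ccc(O)cc2)c2nnn(Cc3ccccc3)c2n1` — 32500 nM
compound 3 `CCCSc1nc(N/N=C/c2c(O)ccc3ccccc23)c2nnn(Cc3ccccc3)c2n1` — 9290 nM

Three compounds of the shared core have been run in a functional assay on ECa-109 cells (Homo sapiens) for antiproliferative activity, read by MTT assay, with a stated time of 72 h; on this read-out higher numbers stand for weaker inhibition and lower numbers for stronger inhibition. Compound 1 returns only a limit, > 64000 nM, and no number. Of the three values, that of compound 1 is the one sitting at the limit (the limit of > 64000 nM in this assay, at which 1 of the 3 values shown sits). The other two, compound 2 at 32500 nM and compound 3 at 9290 nM, are numbers, with compound 3 the lower of the two.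

Compound 4 `CCCSc1nc(N/N=C(\C)c2ccccc2O)c2nnn(Cc3ccc(Cl)cc3)c2n1` is the next compound to be measured in this assay. It differs from compound 1 only in the group on the saturated chain carbon bound to the aromatic nitrogen: 4-chlorophenyl in place of 2-chlorophenyl on a saturated chain carbon bound to an aromatic nitrogen. For the measured compounds named here, no pair of measured compounds differs in this one place, so no step of that kind has been seen.

Since compound 1 gives only the limit > 64000 nM, the step from compound 1 to compound 4 is expected to be small, within the scatter, and the result is expected to stay weak. The step of an at least 1.4-fold lower number from compound 1 to compound 4 (0.15 log units; that floor lies within the scatter) is an estimate. Compound 4 is expected near 45000 nM, between 15000 nM and 130000 nM.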

Compound 4, half-maximal inhibitory concentration: 11200 nM
Compound 4: middle estimate off by 4.0-fold (0.60 log units), on the high side; the measured number lies below the stated range.
By their numbers in this assay, from the lowest: compounds 3 and 4 (each within the scatter of the next); then compound 2. At a limit, above all of these: compound 1.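

In this assay, for the compounds shown here, the change from 2-chlorobenzyl to 4-chlorobenzyl gives an at least 5.7-fold lower number from compound 1 to compound 4 (0.75 log units; beyond the scatter) and leaves the atoms of the compound unchanged, so this place on a saturated chain carbon bound to an aromatic nitrogen responds to where the chlorine sits, which no earlier pair could show. Compound 1 gives a limit of the assay, > 64000 nM and no number. The step is therefore a floor and its full size cannot be read, because compound 1 stands at that limit: the limit of > 64000 nM in this assay, at which 1 of the 4 values shown sits.

Going by these compounds, whether a bromine or a methoxy group in place of the chlorine would give a similar number remains open. On these data alone, compound 2 and compound 3 differ from compound 4 in more than one place, so whether the step carries over to other hydrazones of the shared core also remains open.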